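The source may report more compounds than this note shows. Statements on the series, on what has been measured and on what is new or still open speak of the compounds shown alone.

Among the compounds with values here, compound 2 `C/C1=C\CC[C@@]2(C)O[C@@H]2[C@H]2OC(=O)[C@@H](CN3CCN(C)CC3)[C@@H]2C[C@H]1O` gives 36000 nM in a functional assay on Glioma cells (Homo sapiens) for inhibition, read by MTT assay, with a stated time of 72 h (a lower number here means a stronger inhibitor, a higher number a weaker inhibitor), the highest of the two numbers so far; compound 1 `C/C1=C\CC[C@@]2(C)O[C@@H]2[C@H]2OC(=O)[C@@H](CN3CCCC3)[C@@H]2C[C@H]1O` gives 5000 nM, and a 7.2-fold higher number from compound 1 to compound 2 (0.86 log units; beyond the scatter). Compound 3 `C/C1=C\CC[C@@]2(C)O[C@@H]2[C@H]2OC(=O)[C@@H](CN3CCN(c4ccccc4)CC3)[C@@H]2C[C@H]1O` differs from compound 2 by phenyl in place of methyl on an amine nitrogen in a ring. Within the data shown here, the single measured step swaps the whole group on the saturated chain carbon rather than a group on the ring nitrogen, so it offers no direct guide to this change. For compound 3 the expected step is a 1.2-fold lower number from compound 2 to compound 3 (0.08 log units; within the scatter), within the scatter in either direction. Compound 3 is estimated at 30000 nM, between 9000 nM and 100000 nM.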

Compound 3, half-maximal inhibitory concentration: 5000 nM
Estimate against measurement, compound 3: 6.0-fold (0.78 log units) above; the whole stated range lies above it.
By their numbers in this assay, from the lowest: compounds 1 and 3 (each within the scatter of the next); then compound 2.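

In this assay the group on the ring nitrogen clearly matters: phenyl in place of methyl gives a 7.2-fold lower number from compound 2 to compound 3 (0.86 log units; beyond the scatter) and so a stronger inhibitor, something the earlier swap of the whole amine group could not show for this position. This change also brings compound 3 within the scatter of compound 1, which carries pyrrolidin-1-yl instead. Nothing measured here explains why the phenyl group gives this result. From the compounds shown here alone, whether an ethyl group, a benzyl group or a chlorophenyl group on the same nitrogen would behave like phenyl or like methyl stays open.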